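Replacing the phenylpiperazine by bromine on the acetamide chain

The source may hold more compounds than are shown below. What is called first, only, known or untested is meant among the compounds shown, and "the series" means these compounds.

Compound 2 `O=C(CN1CCN(c2ccccc2)CC1)Nc1ccc(C(=O)/C=C/c2cn(Cc3ccc(Br)cc3)nn2)cc1` is the weaker of the two measured compounds: in a functional assay on A549 cells (Homo sapiens) for inhibition, read by MTT assay (on this read-out higher numbers stand for weaker inhibition and lower numbers for stronger inhibition), compound 2 gives 42100 nM, while compound 1 `O=C(CN1CCN(c2ccccc2F)CC1)Nc1ccc(C(=O)/C=C/c2cn(Cc3ccc(Br)cc3)nn2)cc1` gives 14700 nM. For the measured compounds named here, the only measured step, a 2.9-fold higher number from compound 1 to compound 2 (0.46 log units; beyond the scatter), concerns hydrogen in place of fluoro on an aromatic carbon and leaves the rest of the shared core untouched.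

Compound 3 `O=C(CBr)Nc1ccc(C(=O)/C=C/c2cn(Cc3ccc(Br)cc3)nn2)cc1` differs from compound 2 in a different place: bromo in place of 4-phenylpiperazin-1-yl on a saturated chain carbon bound to a carbonyl carbon. Going by the values given here, none of the measured steps touches this part of the molecule, so the step from compound 1 to compound 2 offers no direct guide to the direction or size of the change in this assay; the whole 4-phenylpiperazin-1-yl group leaves and a single bromine enters, a far larger structural change than the one measured. Among the compounds with values here, with no comparable step available, the expectation for compound 3 must be wide, and the number is estimated to be 10000 nM, in the range 1200 nM to 50000 nM, meaning an expected step of a 4.2-fold lower number from compound 2 to compound 3 (0.62 log units; beyond the scatter).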

Compound 3, half-maximal inhibitory concentration: 8670 nM
The estimate for compound 3 lay 1.2-fold (0.06 log units) above the measured number, and the stated range covers the measured number.
By their numbers in this assay, from the lowest: compounds 3 and 1 (each within the scatter of the next); then compound 2.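

Taking the whole 4-phenylpiperazin-1-yl group off the saturated chain carbon bound to a carbonyl carbon does not cost activity in this assay: with bromo in its place, the change gives a 4.9-fold lower number from compound 2 to compound 3 (0.69 log units; beyond the scatter) and stands as a modest gain. The earlier step had touched only a single aromatic carbon of this group, whereas this one shows that both of its rings can leave and a single bromine can enter, with compound 3 lying within the scatter of compound 1, so neither ring is required to reach the level of activity seen in these compounds. Nothing in the data at hand gives a reason for this step.

The compounds shown leave open whether the bromine itself matters or only the loss of the 4-phenylpiperazin-1-yl group, a question that chlorine, a hydroxyl group or a small amine such as dimethylamino on the same chain carbon would bear on. Also open, going by these compounds, is how a morpholine ring at this place, which keeps a six-membered ring but carries no phenyl group, would compare with compound 2 and compound 3.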